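Fluoro in Place of Methoxy: Expecting Compound 4

This account rests on a few compounds, and the source may have more. Where it says the series, first, only, none or still open, it means among the compounds named here.

The series was tested in a functional assay on MCF7 cells (Homo sapiens) for antiproliferative activity, read by WST assay, with a stated time of 72 h; on this read-out lower numbers stand for stronger inhibition and higher numbers for weaker inhibition. Compound 1, `COc1ccc2[nH]c(-c3nc(C)no3)cc2c1`, gives 16700 nM in this assay. Compound 2, `Cc1noc(-c2cc3cc(F)ccc3[nH]2)n1`, gives 12400 nM. Compound 3, `COc1ccc(-c2noc(-c3cc4cc(OC)ccc4[nH]3)n2)cc1`, returns only a limit of this assay, > 50000 nM, and no number. Compound 4, `COc1ccc(-c2noc(-c3cc4cc(F)ccc4[nH]3)n2)cc1`, has not yet been measured.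

Compound 2 differs from compound 1 by fluoro in place of methoxy on an aromatic carbon; this change gave a 1.3-fold lower number from compound 1 to compound 2 (0.13 log units; within the scatter). Compound 3 differs from compound 1 by 4-methoxyphenyl in place of methyl on an aromatic carbon; this change gave an at least 2.9-fold higher number from compound 1 to compound 3 (0.47 log units; beyond the scatter), so the two cores, that of compound 1 and that of compound 3, differ in that one group.

Compound 4 differs from compound 3 by fluoro in place of methoxy on an aromatic carbon. This is the same change as from compound 1 to compound 2, at the same place. Since that earlier step, a 1.3-fold lower number from compound 1 to compound 2 (0.13 log units; within the scatter), stayed within the scatter, the corresponding step from compound 3 to compound 4 is expected to be small as well; the estimate means a step that the limit leaves unreadable from compound 3 to compound 4. Because compound 3 already sits at the limit of > 50000 nM in this assay, at which 1 of the 3 values shown sits, compound 4 may again return only a limit rather than a number. Compound 4 is therefore estimated at 60000 nM in this assay. Its expected range runs from 25000 nM to 150000 nM.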

Compound 4, half-maximal inhibitory concentration: > 50000 nM
Compound 4: a limit, no number (the forecaster's own chance of this, stated with the estimate: 70%); the middle value lies beyond the limit too.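

Among these compounds, compound 3 and compound 4 both return only a limit in this assay, so no step between them can be read, and the result adds just this: the limit of > 50000 nM in this assay, at which 2 of the 4 values shown sit.

The compounds shown leave open whether fluoro in place of methoxy changes the read-out at all on the core of compound 3, and how far past the limit either compound lies.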